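The compounds below may be only part of what the source reports. "The series", "measured", "known", "first", "only" and "open" are said of these compounds alone.

Measured so far:
compound 1 `Oc1ccccc1-c1cc(-c2ccccc2C(F)(F)F)cc(-c2ccccc2O)n1` with 22500 nM;
compound 2 `Oc1ccccc1-c1cc(-c2cccc(C(F)(F)F)c2)cc(-c2ccccc2O)n1` with > 50000 nM;
compound 3 `Oc1cccc(-c2cc(-c3ccccc3C(F)(F)F)cc(-c3cccc(O)c3)n2)c1` with 4350 nM.

The three compounds were tested in a functional assay on T47D cells (Homo sapiens) for inhibition; on this read-out lower numbers stand for stronger inhibition and higher numbers for weaker inhibition. In this assay compound 1 gives 22500 nM. For compound 2 the read-out is a limit of the assay, > 50000 nM, and not a number. Compound 3 gives 4350 nM, the lowest of the two numbers, and its nearest neighbour is compound 1, whose number is higher by more than the usual scatter. The cores of compound 1 and compound 3 differ by more than one place, and the difference between the two cores is not broken down here.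

The change from compound 1 to compound 2 is 3-(trifluoromethyl)phenyl in place of 2-(trifluoromethyl)phenyl on an aromatic carbon. It made the number worse: an at least 2.2-fold higher number from compound 1 to compound 2 (0.34 log units; beyond the scatter), and because one of the three values sits at the limit of > 50000 nM in this assay, at which 1 of the 3 values shown sits, only the lower bound of that step is known.

The same kind of change leads from compound 3 to the not yet measured compound 4 `Oc1cccc(-c2cc(-c3cccc(C(F)(F)F)c3)cc(-c3cccc(O)c3)n2)c1`: 3-(trifluoromethyl)phenyl in place of 2-(trifluoromethyl)phenyl on an aromatic carbon. The surroundings of the place differ, since in compound 1 the position is meta to two 2-hydroxyphenyl groups, while in compound 3 it is meta to two 3-hydroxyphenyl groups, so the two changes are of the same kind but not the same. Compound 4 is expected to lose potency in this assay in a step of about a 2.8-fold higher number from compound 3 to compound 4 (0.44 log units; beyond the scatter), resting on compound 1 and compound 2 and their step of an at least 2.2-fold higher number from compound 1 to compound 2 (0.34 log units; beyond the scatter). The estimate for compound 4 in this assay is 12000 nM, expected to fall between 5000 nM and 40000 nM.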

Compound 4, half-maximal inhibitory concentration: 4970 nM
For compound 4 the middle estimate is 2.4-fold (0.38 log units) above the measured one; measured number below the stated range.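

On the core of compound 3, with its two 3-hydroxyphenyl groups, 3-(trifluoromethyl)phenyl in place of 2-(trifluoromethyl)phenyl gives a 1.1-fold higher number from compound 3 to compound 4 (0.06 log units; within the scatter) in this assay, so the step beyond the scatter seen on the core of compound 1, an at least 2.2-fold higher number from compound 1 to compound 2 (0.34 log units; beyond the scatter), did not recur here. This shows that, in this series, the earlier step on one core was not a reliable guide to the size of the step on the other, but it does not show that the two steps truly differ: the same change on two cores in this assay, an at least 2.2-fold higher number (0.34 log units; beyond the scatter) from compound 1 to compound 2 and a 1.1-fold higher number (0.06 log units; within the scatter) from compound 3 to compound 4; the limit leaves it open whether they differ. On these data alone, compound 2 gives > 50000 nM in this assay, which is a limit of the assay and not a number, so the earlier step has only a lower bound and its full size remains unknown: the limit of > 50000 nM in this assay, at which 1 of the 4 values shown sits.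

The compounds shown leave open whether the same change would also stay within the scatter on a core carrying other groups in place of the hydroxyphenyl groups, such as methoxyphenyl or aminophenyl groups. They also leave open how a nitrile or a carboxylic acid in place of the trifluoromethyl group would read in this assay on either core.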